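The source may hold more compounds than are shown below. What is called first, only, known or untested is meant among the compounds shown, and "the series" means these compounds.

Compound 1 `O=C1Nc2ccccc2/C1=C1/Nc2ccccc2/C1=N\OCC(O)CSc1nnc(Nc2ccccc2)s1` gives 17700 nM
Compound 2 `Cc1cccc(Nc2nnc(SCC(O)CO/N=C3C(=C4/C(=O)Nc5ccccc54)/Nc4ccccc4/3)s2)c1C` gives 15300 nM
Compound 3 `O=C1/C(=C2/C(=O)N(CC(O)CSc3nnc(Nc4ccccc4)s3)c3ccccc32)Nc2ccccc21` gives 1900 nM

All three values come from a functional assay on HepG2 cells (Homo sapiens) for inhibition (a lower number here means a stronger inhibitor, a higher number a weaker inhibitor), and compound 3 has the lowest number, beyond the scatter from both others. Compound 4 `Cc1ccc(Nc2nnc(SCC(O)CN3C(=O)/C(=C4\Nc5ccccc5C4=O)c4ccccc43)s2)c(C)c1` differs from compound 3 in one place, with 2,4-dimethylphenyl in place of phenyl on a nitrogen on an aromatic ring. Within the data shown here, one measured step bears on this change, a similar swap of phenyl for a dimethylphenyl group (a 1.2-fold lower number from compound 1 to compound 2 (0.06 log units; within the scatter)). It stayed within the scatter, but it involves a different dimethylphenyl group on a different core, so it is only a loose guide. No step beyond the scatter is therefore expected in this assay (a 1.1-fold lower number from compound 3 to compound 4 (0.05 log units; within the scatter)). Compound 4 is estimated at 1700 nM (700 nM to 4000 nM).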

Compound 4, half-maximal inhibitory concentration: 4470 nM
The estimate for compound 4 lay 2.6-fold (0.42 log units) below the measured number; the whole stated range lies below it.
By their numbers in this assay, from the lowest: compound 3; then compound 4; then compounds 2 and 1 (each within the scatter of the next).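

In this assay, the position on the nitrogen of compound 3 is sensitive to this change: 2,4-dimethylphenyl in place of phenyl gives a 2.4-fold higher number from compound 3 to compound 4 (0.37 log units; beyond the scatter) and so a modest loss of inhibition. The earlier step, a 1.2-fold lower number from compound 1 to compound 2 (0.06 log units; within the scatter) and within the scatter, has a different dimethylphenyl group on a different core, so these steps cannot separate the two differences. Nothing available explains the loss.

Still open, going by these compounds, is whether 2,3-dimethylphenyl on the core of compound 3 gives a similar loss. On these data alone, whether a single methyl, a chlorine or a methoxy group there would be tolerated also remains unknown.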